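The source may hold more compounds than are shown below. What is called first, only, known or untested is meant among the compounds shown, and "the series" means these compounds.

Measured so far in an assay for binding affinity to dual specificity mitogen-activated protein kinase kinase 4 (Homo sapiens), read by KINOMEscan, tested at 100 nM; a higher number here means a weaker effect of the compound at the concentration tested, a lower number a stronger effect:
Compound 1, `CCCS(=O)(=O)Nc1ccc(F)c(C(=O)c2n[nH]c3ncc(-c4cccc(F)c4)cc23)c1F`, gives 8.2%.
Compound 2, `CCCS(=O)(=O)Nc1ccc(F)c(C(=O)c2n[nH]c3ncc(-c4cccc(C)c4)cc23)c1F`, gives 15%.
Compound 3, `CCCS(=O)(=O)Nc1ccc(F)c(C(=O)c2n[nH]c3ncc(-c4ccccc4OC)cc23)c1F`, gives 1.9%.

Compound 1 stands second highest of these three numbers. Its nearest neighbour is compound 3, a number 6.3 percentage points lower from compound 1 to compound 3 (within the scatter); its furthest is compound 2, a number 6.8 percentage points higher from compound 1 to compound 2 (within the scatter). Both of those steps lie within the scatter, so the three aryl groups tried so far on the shared core cannot be told apart with confidence, even though the pair without compound 1 shows a number 13.1 percentage points lower from compound 2 to compound 3 (beyond the scatter), a modest step.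

Compound 4, `CCCS(=O)(=O)Nc1ccc(F)c(C(=O)c2n[nH]c3ncc(-c4ccc(O)cc4)cc23)c1F`, has not been measured. It differs from compound 1 in one place: 4-hydroxyphenyl in place of 3-fluorophenyl on an aromatic carbon.

Within the data shown here, the steps that bear on this change are the two that also swap the aryl group on compound 1, namely a number 6.8 percentage points higher from compound 1 to compound 2 (within the scatter) and a number 6.3 percentage points lower from compound 1 to compound 3 (within the scatter), both within the scatter. Among the measured compounds shown here, none of the measured steps introduces a hydroxyl, so there is no direct evidence for this particular group. The expectation is therefore a step within the scatter in this assay, in no clear direction.

Compound 4 is expected to give 8%, within a range from 1.5% to 25%, which means an expected step of a number 0.2 percentage points lower from compound 1 to compound 4 (within the scatter).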

Compound 4, a percentage reported as activity, at one concentration (the size of the read-out at that concentration, not a potency): 0.75%
Compound 4: the middle estimate sits 7.3 percentage points above what was measured, outside the stated range (below it).
By their numbers in this assay, from the lowest: compounds 4, 3, 1 and 2 (each within the scatter of the next, the first and the last beyond it).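

Replacing the 3-fluorophenyl with a 4-hydroxyphenyl, which carries a hydrogen-bond donor and acceptor that the 3-fluorophenyl lacks, brings no clear change at this position of the shared core in this assay: the result is a number 7.5 percentage points lower from compound 1 to compound 4 (within the scatter) and, against the 2-methoxyphenyl, a number 1.2 percentage points lower from compound 3 to compound 4 (within the scatter) in this assay. Only the comparison with the 3-methylphenyl is clear, at a number 14.3 percentage points lower from compound 2 to compound 4 (beyond the scatter), so compound 2 now stands apart from both compound 3 and compound 4, while compound 1 still cannot be separated from any of the others. Nothing shown here accounts for these differences.

Going by these compounds, it remains open whether a 3-hydroxyphenyl would match the 4-hydroxyphenyl, and whether an aminophenyl or a ring bearing a carboxylic acid would also be accepted. On these data alone, with one concentration per compound, the ranking of compound 3 and compound 4 in a true potency measurement also remains open.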